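The source may report more compounds than this note shows. Statements on the series, on what has been measured and on what is new or still open speak of the compounds shown alone.

Of the compounds shown here, three built on one shared core have been tested in a functional assay on HEK293 cells for antagonist activity at thromboxane A2 receptor (Homo sapiens), read by fluorescence and calcium flux; a higher number here means a weaker inhibitor, a lower number a stronger inhibitor. Compound 1 `Cc1ccccc1Oc1ccc(C#N)cc1S(=O)(=O)NC(=O)NC(C)C` gives 8680 nM in this assay. Compound 2 `Cc1ccccc1Oc1ccc(C#N)cc1S(=O)(=O)NC(=O)NC(C)(C)C` gives 3690 nM, and compound 3 `Cc1cccc(Oc2ccc(C#N)cc2S(=O)(=O)NC(=O)NC(C)C)c1` gives 2380 nM. Compound 3 thus has the lowest of the three numbers; its gap to compound 1 is beyond the scatter, whereas its gap to compound 2 lies within the scatter, so compound 3 and compound 2 cannot be told apart by these figures.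

Compound 4 `Cc1cccc(Oc2ccc(C#N)cc2S(=O)(=O)NC(=O)NC(C)(C)C)c1` has not yet been measured in this assay. It differs from compound 3 by methyl in place of hydrogen on a saturated chain carbon bound to an amide-type nitrogen and two saturated chain carbons. The same change has already been made once within this set, in the other phenyl series: a 2.4-fold lower number from compound 1 to compound 2 (0.37 log units; beyond the scatter). The other measured step, a 3.6-fold lower number from compound 1 to compound 3 (0.56 log units; beyond the scatter), changes a different part of the molecule and does not speak to the present change. On that single precedent, a modest downward step is expected: a 2.4-fold lower number from compound 3 to compound 4 (0.38 log units; beyond the scatter). Compound 4 is therefore estimated to give about 1000 nM, with a likely range from 400 nM to 2500 nM.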

Compound 4, half-maximal inhibitory concentration: 1050 nM
Compound 4: middle estimate off by 1.1-fold (0.02 log units), on the low side, and the stated range covers the measured number.
By their numbers in this assay, from the lowest: compound 4; then compounds 3 and 2 (each within the scatter of the next); then compound 1.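

Going from isopropyl to tert-butyl, this assay shows a 2.3-fold lower number from compound 3 to compound 4 (0.36 log units; beyond the scatter), which gives this change on the saturated chain carbon a second example, and the two steps match: the same change on two cores in this assay, a 2.4-fold lower number (0.37 log units; beyond the scatter) from compound 1 to compound 2 and a 2.3-fold lower number (0.36 log units; beyond the scatter) from compound 3 to compound 4, 1.0-fold (0.02 log units) apart, within the scatter of two such steps

The change from 2-methylphenyl to 3-methylphenyl on the oxygen, now seen with tert-butyl as well, gives a 3.5-fold lower number from compound 2 to compound 4 (0.55 log units; beyond the scatter), and it repeats too: the same change on two cores in this assay, a 3.6-fold lower number (0.56 log units; beyond the scatter) from compound 1 to compound 3 and a 3.5-fold lower number (0.55 log units; beyond the scatter) from compound 2 to compound 4, 1.0-fold (0.02 log units) apart, within the scatter of two such steps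

Across these four compounds the two changes simply add, the size of each staying the same whichever form the other part takes, and no compound goes against this.

As far as these compounds go, it remains open whether a cyclohexyl ring or a longer chain such as n-butyl in place of tert-butyl would lower the number further, and whether the steps would hold with an unsubstituted phenyl on the oxygen. From the compounds shown here alone, the effect of a carboxylic acid in place of the nitrile also remains open.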